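Removing a methyl from a chalcone-bearing series

A few compounds are considered here, and "the series" means these few. Any claim that something is new, unique, unknown or untested is made for them only; others in the source may bear on it.

Compound 2 `COc1ccc(-c2cc(C(=O)/C=C/c3ccc(C)cc3)nc3cc(-c4ccccc4)nn23)cc1OC` gives 22600 nM in a functional assay on MDA-MB-231 cells (Homo sapiens) for antiproliferative activity, read by MTT assay, with a stated time of 24 h (a lower number here means a stronger inhibitor, a higher number a weaker inhibitor), and compound 1 `COc1ccc(-c2cc(C(=O)/C=C/c3ccccc3)nc3cc(-c4ccccc4)nn23)cc1OC` gives 23300 nM there. The change between them, (hydrogen in place of methyl on an aromatic carbon), made a step of a 1.0-fold higher number from compound 2 to compound 1 (0.01 log units; within the scatter). Compound 3 `COc1cc(-c2cc(/C=C/C(=O)c3ccc(C)cc3)nc3cc(-c4ccccc4)nn23)cc(OC)c1OC` carries a different core, and how it differs from compound 2 is not broken down here; in this assay compound 3 gives 23900 nM, which sits close to both other values. Compound 4 `COc1cc(-c2cc(/C=C/C(=O)c3ccccc3)nc3cc(-c4ccccc4)nn23)cc(OC)c1OC` is not yet measured. It stands to compound 3 as compound 1 stands to compound 2, through the same change, (hydrogen in place of methyl on an aromatic carbon), at the same place. Because a 1.0-fold higher number from compound 2 to compound 1 (0.01 log units; within the scatter) stayed within the scatter, the step expected for compound 4 is a 1.0-fold lower number from compound 3 to compound 4 (0.01 log units; within the scatter). Compound 4 is therefore expected to give about 23500 nM in this assay, estimated between 12000 nM and 46000 nM.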

Compound 4, half-maximal inhibitory concentration: 15800 nM
Compound 4: middle estimate off by 1.5-fold (0.17 log units), on the high side, within the range that was stated.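

In this assay, replacing the methyl with hydrogen on the core of compound 3 gave a 1.5-fold lower number from compound 3 to compound 4 (0.18 log units; within the scatter). Set beside the earlier step, the change shows no difference that can be told apart between the two cores: the same change on two cores in this assay, a 1.0-fold higher number (0.01 log units; within the scatter) from compound 2 to compound 1 and a 1.5-fold lower number (0.18 log units; within the scatter) from compound 3 to compound 4, 1.6-fold (0.19 log units) apart, within the scatter of two such steps. This shows that removing the methyl had no effect beyond the scatter on either core in this assay, but it does not show that the two cores respond identically or that the result extends to any other core.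

The compounds shown leave open what an amine, a carboxylic acid or a longer chain would do in place of the methyl. They also leave open whether the same step would hold in another cell line.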